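A few compounds are considered here, and "the series" means these few. Any claim that something is new, unique, unknown or untested is made for them only; others in the source may bear on it.

Three compounds that share one core, each carrying a chloromethyl-substituted benzyl group, have been tested in a functional assay on OVCAR-5 cells (Homo sapiens) for cytotoxicity, read by sulforhodamine B assay, with a stated time of 48 h; a lower number here means a stronger inhibitor of growth, a higher number a weaker inhibitor of growth. Compound 1 `ClCc1ccc(Cn2cnc3c(Cl)ncnc32)cc1` gives 2950 nM in this assay. Compound 2 `ClCc1cccc(Cn2cnc3c(Cl)ncnc32)c1` gives 2080 nM, the lowest of the three numbers, although its gaps to the other two lie within the usual scatter. Compound 3 `ClCc1ccc(Cn2cnc3nc(Cl)nc(Cl)c32)cc1` gives 2180 nM. Compound 3 carries one more chloro on the core than compound 1, and the two numbers sit within the scatter of each other.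

Compound 4 `ClCc1cccc(Cn2cnc3c(Cl)nc(Cl)nc32)c1` has not yet been measured. It differs from compound 2 by a single change: chloro in place of hydrogen on an aromatic carbon. For the measured compounds named here, no step of exactly this kind is known from a measured pair, so the expectation rests on the values of compound 1 and compound 3 set side by side. The step is therefore expected to be none beyond the scatter, a 1.0-fold lower number from compound 2 to compound 4 (0.02 log units; within the scatter). On that basis compound 4 is estimated at 2000 nM in this assay, with a range from 1000 nM to 4000 nM.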

Compound 4, concentration for 50% growth inhibition: 6450 nM
For compound 4 the middle estimate is 3.2-fold (0.51 log units) below the measured one, outside the stated range (above it).
By their numbers in this assay, from the lowest: compounds 2, 3 and 1 (each within the scatter of the next); then compound 4.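

Putting a chloro on the aromatic carbon between two ring nitrogen atoms of the shared core gives a 3.1-fold higher number from compound 2 to compound 4 (0.49 log units; beyond the scatter) in this assay, which means weaker growth inhibition. For the compounds shown here, this is the first step in the set that goes beyond the usual scatter, so this carbon is a place where even a single added chlorine atom can shift the read-out, although the step is modest and rests on one pair. Nothing shown here accounts for the rise.

From the compounds shown here alone, whether an amine or a methoxy group on the same carbon would move the number in the same direction remains open. Going by these compounds, it is also open whether this chloro would give a step of similar size on compound 1, which carries its chloromethyl group at a different place on the benzyl ring.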